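Ester to Morpholine Amide: Expected Effect on Calcium Channel Inhibition

The source may hold more compounds than are shown below. What is called first, only, known or untested is meant among the compounds shown, and "the series" means these compounds.

Compound 1 `COC(=O)C1=C(C)NC(C)=C(C(=O)OC)C1c1cccc(OCC(=O)N2CCCC2)c1`: 3600 nM
Compound 2 `COC(=O)COc1cccc(C2C(C(=O)OC)=C(C)NC(C)=C2C(=O)OC)c1`: 10000 nM
Compound 3 `COC(=O)C1=C(C)NC(C)=C(C(=O)OC)C1c1ccc(OCC(=O)N2CCN(C)CC2)c(OC)c1`: 9100 nM

All three were tested in an assay on cells for inhibition of Voltage-gated L-type calcium channel (Rattus norvegicus), read by fluorescence and calcium flux, with stated times of 30 min and 2 min; a higher number here means a weaker inhibitor, a lower number a stronger inhibitor. Compound 2 gives the highest number of the three; compound 3 sits within the scatter of it, while compound 1 lies lower by a margin beyond the scatter. Compound 4 `COC(=O)C1=C(C)NC(C)=C(C(=O)OC)C1c1cccc(OCC(=O)N2CCOCC2)c1` differs from compound 2 by morpholin-4-yl in place of methoxy on a carbonyl carbon. Among the measured compounds shown here, the one measured step that bears on this change is a 2.8-fold higher number from compound 1 to compound 2 (0.44 log units; beyond the scatter), where a pyrrolidin-1-yl amide was exchanged for the methyl ester; the move to a morpholin-4-yl amide is the reverse of that exchange with a related ring. Compound 3 carries a different amide together with a second change, so only its value stands beside that of compound 2. Compound 4 is therefore expected to show a 2.2-fold lower number from compound 2 to compound 4 (0.35 log units; beyond the scatter) in this assay. The estimate for compound 4 is 4500 nM, with a range from 2000 nM to 10000 nM.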

Compound 4, half-maximal inhibitory concentration: 9900 nM
Beside the measured number, compound 4's estimate is 2.2-fold (0.34 log units) below it, within the range that was stated.
By their numbers in this assay, from the lowest: compound 1; then compounds 3, 4 and 2 (each within the scatter of the next).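

In this assay, the amide on this carbonyl carbon does not by itself lower the number: the record shows a 1.0-fold lower number from compound 2 to compound 4 (0.00 log units; within the scatter) for the exchange of methoxy for morpholin-4-yl, and a 2.8-fold higher number from compound 1 to compound 4 (0.44 log units; beyond the scatter) for the exchange of one ring for the other. At this place, then, the two rings differ, and only the pyrrolidin-1-yl amide stands apart from the methyl ester. No evidence is available to explain that difference. The compounds shown leave open how a piperidin-1-yl amide, a dimethylamino amide or a free carboxylic acid would read on the same carbonyl carbon.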